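A few compounds are considered here, and "the series" means these few. Any claim that something is new, unique, unknown or untested is made for them only; others in the source may bear on it.

Measured in a functional assay on HepG2 cells (Homo sapiens) for antiproliferative activity, read by MTT assay, with a stated time of 48 h; a lower number here means a stronger inhibitor, a higher number a weaker inhibitor:
- Compound 1 `CCOc1ccc(-c2nc(N(Cc3ccccc3)Cc3ccccc3)sc2-c2cc(OC)c(OC)c(OC)c2)cc1`: > 5000 nM, a limit.
- Compound 2 `CCOc1ccc(-c2sc(N)nc2-c2cc(OC)c(OC)c(OC)c2)cc1`: 8.3 nM.
- Compound 3 `CCOc1ccc(-c2nc(NS(=O)(=O)c3ccccc3C(F)(F)F)sc2-c2cc(OC)c(OC)c(OC)c2)cc1`: > 5000 nM, a limit.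

Compound 3 stands at the limit of > 5000 nM in this assay, at which 2 of the 3 values shown sit. Its value is a limit and not a number. Compound 2 is the only one of the three with a numerical value.

Compound 4 `CCOc1ccc(-c2nc(NS(=O)(=O)c3ccc(OC)c(F)c3)sc2-c2cc(OC)c(OC)c(OC)c2)cc1` carries 3-fluoro-4-methoxyphenyl in place of 2-(trifluoromethyl)phenyl on a sulfonyl sulfur. Compound 3, with its limit of > 5000 nM, is the sole basis for this expectation, so only a small gain in this assay is expected, and another limit would be unsurprising. The estimated change is an at least 1.2-fold lower number from compound 3 to compound 4 (0.09 log units; that floor lies within the scatter). For compound 4 the estimate is 4000 nM, with an expected range of 600 nM to 10000 nM.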

Compound 4, half-maximal inhibitory concentration: > 5000 nM
Compound 4: no number, only a limit (the forecaster's own chance of this, stated with the estimate: 60%); at least 1.2-fold (0.09 log units) between middle value and limit.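

Compound 3 and compound 4 both give only a limit and no number, so no step can be read between them: the limit of > 5000 nM in this assay, at which 3 of the 4 values shown sit.

The compounds shown leave open whether 3-fluoro-4-methoxyphenyl and 2-(trifluoromethyl)phenyl on a sulfonyl sulfur differ at all in antiproliferative activity.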